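Nitro to fluoro swap: compound 2 to compound 3

This account rests on a few compounds, and the source may have more. Where it says the series, first, only, none or still open, it means among the compounds named here.

Measured so far in a functional assay on SH-SY5Y cells (Homo sapiens) for cytotoxicity, read by MTT assay, with stated times of 8 h, 30 min and 12 h, tested at 0.5 uM; on this read-out higher numbers stand for a stronger effect at the one concentration tested and lower numbers for a weaker effect:
compound 1, `N=C(NCc1ccccc1)[C@@H]1CCC(=O)N1Cc1ccccc1`, 27.9%
compound 2, `N=C(NCc1ccccc1)[C@@H]1CCC(=O)N1Cc1ccc([N+](=O)[O-])cc1`, 24%

Compound 2 holds the lower of the two numbers, with compound 1 within the scatter of it: the step of a number 3.9 percentage points lower from compound 1 to compound 2 (within the scatter). Compound 3, `N=C(NCc1ccccc1)[C@@H]1CCC(=O)N1Cc1ccc(F)cc1`, is the next member, differing from compound 2 as follows.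

fluoro in place of nitro on an aromatic carbon

Going by the values given here, the only measured step that bears on this change is the one putting nitro in place of hydrogen on an aromatic carbon, and it stayed within the scatter. The expectation for compound 3 is therefore no step beyond the scatter, a number 2 percentage points higher from compound 2 to compound 3 (within the scatter). The estimated value for compound 3 is 26%, in the range 15% to 37%.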

Compound 3, a percentage reported as activity, at one concentration (the size of the read-out at that concentration, not a potency): 23.3%
Compound 3: middle estimate off by 2.7 percentage points, on the high side; the range from low to high includes it.
By their numbers in this assay, from the lowest: compounds 3, 2 and 1 (each within the scatter of the next).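

Exchanging hydrogen for fluoro on the aromatic ring gives a number 4.6 percentage points lower from compound 1 to compound 3 (within the scatter) in this assay, and fluoro in place of nitro gives a number 0.7 percentage points lower from compound 2 to compound 3 (within the scatter). At this place, para to a large group, hydrogen, nitro and fluoro therefore cannot be told apart on this read-out. No available evidence bears on this result. On these data alone, whether an amine or a carboxylic acid at the same place would give a step beyond the scatter stays open. So does the effect of changes elsewhere on the shared core.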